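A 4-hydroxyphenyl group in place of thiophen-2-yl

A few compounds are considered here, and "the series" means these few. Any claim that something is new, unique, unknown or untested is made for them only; others in the source may bear on it.

Of the compounds shown here, three sharing one core have been measured so far. In a functional assay on K562 cells (Homo sapiens) for antiproliferative activity, read by MTT assay, with a stated time of 24 h (a lower number here means a stronger inhibitor, a higher number a weaker inhibitor), compound 1 (`COc1ccc(C(=O)/C=C/c2ccc(C(F)(F)F)cc2)c2c1C=CC(C)(C)O2`) gives > 10000 nM as a limit and not a number. Compound 2 (`COc1ccc(C(=O)/C=C/c2ccsc2)c2c1C=CC(C)(C)O2`) gives > 10000 nM as a limit as well. Compound 3 (`COc1ccc(C(=O)/C=C/c2cccs2)c2c1C=CC(C)(C)O2`) gives > 10000 nM as a limit too, so it has no number of its own in this assay and its place can be told only from that limit. The set as a whole shows the limit of > 10000 nM in this assay, at which 3 of the 3 values shown sit, and nothing beyond it.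

Compound 4 (`COc1ccc(C(=O)/C=C/c2ccc(O)cc2)c2c1C=CC(C)(C)O2`) follows from compound 3 by one change, 4-hydroxyphenyl in place of thiophen-2-yl on a double-bonded chain carbon bound to a double-bonded chain carbon and the new group is 4-hydroxyphenyl, on a double-bonded chain carbon bound to a double-bonded chain carbon. Among the measured compounds shown here, the one measured step at this place is a step that the two limits leave unreadable from compound 2 to compound 3 and it gives no size to carry over. None of the three measured compounds carries 4-hydroxyphenyl. The expectation therefore rests on compound 3 at > 10000 nM as a limit. The expected change, a step that the limit leaves unreadable from compound 3 to compound 4, is estimated to lie within the scatter, with no direction expected, and another limit would be no surprise. Compound 4 is estimated at 12000 nM, with an expected range from 4000 nM to 30000 nM.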

Compound 4, half-maximal inhibitory concentration: > 10000 nM
Compound 4 was reported as a limit; the forecaster's own chance of this, stated with the estimate: 70%; the middle value does not contradict the limit.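

In this assay compound 4 gives > 10000 nM, a limit and not a number, so no new step can be read from it to compound 1, compound 2 or compound 3. The compounds shown leave open how the groups carried on the chain of the shared core rank against one another in this assay, with every value at one limit: the limit of > 10000 nM in this assay, at which 4 of the 4 values shown sit.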